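Mirror-Image Partner of a Tolyl Triazole: Cytotoxicity Forecast

This account rests on a few compounds, and the source may have more. Where it says the series, first, only, none or still open, it means among the compounds named here.

Measured compounds:
compound 1, `CC[C@@H](CCn1cncn1)c1ccccc1`, 91.2 ug/mL
compound 2, `CC[C@@H](CCn1cncn1)c1ccc(F)cc1`, 91.6 ug/mL
compound 3, `CC[C@H](CCn1cncn1)c1ccc(C)cc1`, 85.2 ug/mL

Of the compounds shown here, three share one core and have been tested in an ADME assay on RD cells (Homo sapiens) for cytotoxicity, read by MTT assay, with a stated time of 3 days; on this read-out higher numbers stand for lower toxicity in this test and lower numbers for higher toxicity in this test. Compound 1 gives 91.2 ug/mL, compound 2 gives 91.6 ug/mL, and compound 3 gives 85.2 ug/mL. Going by the values given here, the one measured step, a 1.0-fold higher number from compound 1 to compound 2 (0.00 log units; within the scatter), changes nothing that can be told apart from repeat measurements. Compound 3 sits within the usual scatter of both compound 1 and compound 2, so the three numbers are, for practical purposes, one number.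

Compound 4, `CC[C@@H](CCn1cncn1)c1ccc(C)cc1`, is the unmeasured partner of compound 3. The difference is the two compounds have the same atoms and bonds and differ only in configuration as drawn: 1 of 1 stereo elements differ; a stereocentre at a saturated chain carbon is drawn R in compound 3 and S in compound 4. No measured pair among these compounds differs in configuration alone, so no step on record bears directly on this change; all that the data show is that swapping a ring substituent left the read-out in this assay unchanged.

With nothing to point either way, the expectation for the step of a 1.0-fold higher number from compound 3 to compound 4 (0.00 log units; within the scatter) is no change beyond the scatter. Compound 4 is therefore estimated at 86 ug/mL in this assay, with a range of 58 ug/mL to 125 ug/mL.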

Compound 4, half-maximal cytotoxic concentration: 79.4 ug/mL
For compound 4 the middle estimate is 1.1-fold (0.03 log units) above the measured one; the measured number falls inside the stated range.
By their numbers in this assay, from the lowest: compounds 4, 3, 1 and 2 (each within the scatter of the next).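

In this assay, going by these compounds alone, turning the stereocentre at the saturated chain carbon around gives a 1.1-fold lower number from compound 3 to compound 4 (0.03 log units; within the scatter), the first step here that tests configuration at this position. The comparison isolates that single feature, with no group entering or leaving: the fact that compounds 3 and 4 differ only in the configuration as drawn Compound 4 also links the methyl-bearing ring to the two earlier ring variants: methyl in place of fluoro gives a 1.2-fold lower number from compound 2 to compound 4 (0.06 log units; within the scatter), and methyl in place of hydrogen gives a 1.1-fold lower number from compound 1 to compound 4 (0.06 log units; within the scatter), so neither the configuration nor any of these three ring substituents separates these compounds in this test.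

Only one mirror-image pair is shown, so it remains open whether the same holds for the ring bearing fluoro or the unsubstituted ring once their configuration is reversed. The ring substituents shown are also limited to hydrogen, fluoro and methyl, which leaves open whether an amine or a carboxylic acid on the ring, or a longer chain in the shared core, would bring a step beyond the scatter or make the configuration matter.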